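The compounds below may be only part of what the source reports. "The series", "measured", "known", "first", "only" and "open" are said of these compounds alone.

Measured so far in a functional assay on SGC-7901 cells (Homo sapiens) for inhibition, read by MTT assay, with a stated time of 24 h; on this read-out lower numbers stand for stronger inhibition and higher numbers for weaker inhibition:
Compound 1 `CC1(C)[C@H]2CC[C@]1(C)N(Cc1cn(-c3ccccc3Cl)nn1)C(=O)C2` gives 220 nM.
Compound 2 `COc1ccccc1-n1cc(CN2C(=O)C[C@@H]3CC[C@@]2(C)C3(C)C)nn1` gives 280 nM.

Compound 2 stands at the higher of these two numbers, but the step of a 1.3-fold higher number from compound 1 to compound 2 (0.10 log units; within the scatter) lies within the scatter, so the two compounds cannot be separated on these data. Compound 3 `COc1cccc(-n2cc(CN3C(=O)C[C@@H]4CC[C@@]3(C)C4(C)C)nn2)c1` holds the same atoms joined differently: 3-methoxyphenyl in place of 2-methoxyphenyl on an aromatic nitrogen. Within the data shown here, only one measured step touches this ring, the exchange of one group for another in a 1.3-fold higher number from compound 1 to compound 2 (0.10 log units; within the scatter), and it stayed within the scatter; no measured step shifts a group to a different place on the ring, so there is no direct guide for this change. Since a 1.3-fold higher number from compound 1 to compound 2 (0.10 log units; within the scatter) barely moved the read-out, compound 3 is expected to land close to compound 2. The expected step is a 1.1-fold higher number from compound 2 to compound 3 (0.03 log units; within the scatter), which would stay within the scatter. Compound 3 is estimated at 300 nM in this assay, with a range from 120 nM to 750 nM.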

Compound 3, half-maximal inhibitory concentration: 590 nM
Beside the measured number, compound 3's estimate is 2.0-fold (0.29 log units) below it, within the range that was stated.
By their numbers in this assay, from the lowest: compounds 1 and 2 (each within the scatter of the next); then compound 3.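

In this assay, among these compounds, the exchange of chloro for methoxy gave no step that could be told from the scatter, but the same atoms arranged as 3-methoxyphenyl rather than 2-methoxyphenyl give a modest weakening beyond it (a 2.1-fold higher number from compound 2 to compound 3 (0.32 log units; beyond the scatter)). So at this aromatic nitrogen, the place of the methoxy on the phenyl ring can change the read-out even though no atom is added or lost, and the 3-methoxyphenyl compound also stands apart from the 2-chlorophenyl one (a 2.7-fold higher number from compound 1 to compound 3 (0.43 log units; beyond the scatter)). Nothing available explains why this rearrangement changes the read-out.

From the compounds shown here alone, it remains open whether the same shift on the phenyl ring would appear with a group other than methoxy, such as an amine or a carboxylic acid. Going by these compounds, it is also open whether an unsubstituted phenyl ring would sit closer to compound 2 or to compound 3.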